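Working notes on a fused bicyclic amide series

A few compounds are considered here, and "the series" means these few. Any claim that something is new, unique, unknown or untested is made for them only; others in the source may bear on it.

compound 1 `NC(=O)c1c(NC(=O)c2ccccc2F)sc2c1CCN(Cc1c(Cl)cccc1Cl)C2` 10300 nM
compound 2 `NC(=O)c1c(NC(=O)c2cccc([N+](=O)[O-])c2)sc2c1CCN(Cc1c(Cl)cccc1Cl)C2` 18400 nM

In a functional assay on HL-60 cells (Homo sapiens) for antiproliferative activity, with a stated time of 24 h (on this read-out lower numbers stand for stronger inhibition and higher numbers for weaker inhibition), compound 1 gives 10300 nM and compound 2 gives 18400 nM. The step of a 1.8-fold higher number from compound 1 to compound 2 (0.25 log units; within the scatter) keeps the two within the scatter of each other, so compound 1 stands level with compound 2 rather than apart from it.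

Compound 3 `NC(=O)c1c(NC(=O)c2ccccc2F)sc2c1CCN(C(=O)Nc1ccccc1Cl)C2` differs from compound 1 in (2-chlorophenyl)carbamoyl in place of 2,6-dichlorobenzyl on an amine nitrogen in a ring. Within the data shown here, the one measured step alters the aryl on the carbonyl carbon and leaves the amine nitrogen in the ring untouched, so nothing measured bears on this change. With no guidance either way, the default expectation is no shift beyond the scatter, with a wide range. Compound 3 is estimated at 10000 nM, between 2500 nM and 40000 nM. The expected step is a 1.0-fold lower number from compound 1 to compound 3 (0.01 log units; within the scatter).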

Compound 3, half-maximal inhibitory concentration: 32700 nM
Estimate against measurement, compound 3: 3.3-fold (0.51 log units) below; low and high end bracket the measured number.
By their numbers in this assay, from the lowest: compounds 1, 2 and 3 (each within the scatter of the next, the first and the last beyond it).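

Among these compounds, on the amine nitrogen in the ring, this assay responds to the substituent: a 3.2-fold higher number from compound 1 to compound 3 (0.50 log units; beyond the scatter) is a modest step beyond the scatter, the first such step. The aryl change on the carbonyl carbon stayed within the scatter, so only this position has so far shifted the read-out. No evidence on hand accounts for the step.

On these data alone, the change swaps the link and removes a chlorine together, so their shares remain open. A 2-chlorobenzyl or (2,6-dichlorophenyl)carbamoyl group on this nitrogen would separate them.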